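The source may hold more compounds than are shown below. What is called first, only, known or untested is meant among the compounds shown, and "the series" means these compounds.

Compound 1 `C=CC(=O)Nc1cccc(NC(=O)CSc2nc(Nc3ccccc3Br)c3ccccc3n2)c1` gives 15200 nM.
Compound 2 `C=CC(=O)Nc1cccc(NC(=O)CSc2nc(Nc3ccc(Br)cc3)c3ccccc3n2)c1` gives 17300 nM.

Both compounds were tested in a functional assay on MDA-MB-231 cells (Homo sapiens) for inhibition, read by MTT assay, with a stated time of 72 h; a lower number here means a stronger inhibitor, a higher number a weaker inhibitor. The two numbers lie close together: the step of a 1.1-fold higher number from compound 1 to compound 2 (0.06 log units; within the scatter) falls within the usual scatter of repeated measurements, so compound 2 and compound 1 cannot be told apart as inhibitors on these data, and neither can be called the stronger or the weaker of the pair.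

Compound 3 `C=CC(=O)Nc1cccc(NC(=O)CSc2nc(Nc3ccc(CC)cc3)c3ccccc3n2)c1` is not yet measured. It differs from compound 2 in one place: ethyl in place of bromo on an aromatic carbon. Within the data shown here, the only measured step, from compound 1 to compound 2, moved the bromo group from one position on the phenyl ring to another without a change beyond the scatter; no measured step replaces bromo by ethyl, so the effect of that exchange is unknown here. Among the measured compounds shown here, with the one step close to zero, and no evidence that this part of the molecule shifts the number, the expected step of a 1.2-fold lower number from compound 2 to compound 3 (0.09 log units; within the scatter) is small, in no clear direction. Compound 3 is therefore estimated at 14000 nM, with a range from 5500 nM to 36000 nM.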

Compound 3, half-maximal inhibitory concentration: 14400 nM
Compound 3: middle estimate off by 1.0-fold (0.01 log units), on the low side; measured number inside the range.
By their numbers in this assay, from the lowest: compounds 3, 1 and 2 (each within the scatter of the next).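

Putting ethyl in place of bromo on the phenyl ring, two carbon atoms for one bromine atom, gives a 1.2-fold lower number from compound 2 to compound 3 (0.08 log units; within the scatter) in this assay and leaves the two compounds impossible to tell apart as inhibitors, so this position has now tolerated a change of group as well as the earlier shift of bromo around the ring. The larger swap of 4-ethylphenyl in place of 2-bromophenyl gives a 1.1-fold lower number from compound 1 to compound 3 (0.02 log units; within the scatter) and also stays within the scatter, which means that none of the three compounds can be called stronger or weaker than the others, and the number has not yet responded to any change made on this ring. No measurement is available that could explain this lack of response.

Ethyl and bromo both carry no charge and no hydrogen-bond donor or acceptor, so it remains open whether an amine, a carboxylic acid or a longer chain such as hexyl on this ring would shift the number. Going by these compounds, all three compounds also share the rest of their structure, so how much any other part of the molecule contributes to the number is equally open.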